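The source may hold more compounds than are shown below. What is called first, only, known or untested is meant among the compounds shown, and "the series" means these compounds.

Measured so far:
- compound 2 `CCN(CC)CCCCOc1c(OCc2ccccc2)cc2oc(-c3ccccc3)cc(=O)c2c1O`: in a functional assay on A549 cells (Homo sapiens) for antiproliferative activity, read by MTT assay, with a stated time of 48 h (a lower number here means a stronger inhibitor, a higher number a weaker inhibitor), compound 2 gives 1800 nM
- compound 1 `CN1CCN(CCCCOc2c(O)cc3oc(-c4ccccc4)cc(=O)c3c2O)CC1`: in this assay compound 1 gives only a limit of the assay, > 100000 nM

Within the data shown here, compound 2 therefore stands as the only compound with a number here; the other value shown is a limit, as the limit of > 100000 nM in this assay, at which 1 of the 2 values shown sits, states. Compound 3 `O=c1cc(-c2ccccc2)oc2cc(OCc3ccccc3)c(OCCCN3CCCC3)c(O)c12` differs from compound 2 in one place: pyrrolidin-1-yl in place of (diethylamino)methyl on a saturated chain carbon, three bonds along the chain from an oxygen on an aromatic ring. Among the measured compounds shown here, no measured pair here shows such a change, so the step is expected to be small, with no clear direction beyond the scatter. Compound 3 is thus estimated at 1800 nM, between 700 nM and 4500 nM, a step of no change at the digits printed from compound 2 to compound 3 (within the scatter).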

Compound 3, half-maximal inhibitory concentration: 1400 nM
Estimate against measurement, compound 3: 1.3-fold (0.11 log units) above, within the range that was stated.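

In this assay, replacing 4-(diethylamino)butyl with 3-(pyrrolidin-1-yl)propyl gives a 1.3-fold lower number from compound 2 to compound 3 (0.11 log units; within the scatter). Among these compounds, this is the first comparison at this position, and it shows that an open-chain amine and a ring amine on a shorter chain cannot be told apart here. Compound 1 gives only a limit, not a number, and differs from compound 2 and compound 3 in more than one place, so it cannot be compared with either: the limit of > 100000 nM in this assay, at which 1 of the 3 values shown sits.

On these data alone, a morpholine or a carboxylic acid at the chain end remains open. So does a longer chain carrying the pyrrolidine.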